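The compounds below may be only part of what the source reports. "The series", "measured", "known", "first", "only" and "open" are said of these compounds alone.

Measured in a functional assay with Homo sapiens as the target; a lower number here means a stronger inhibitor, a higher number a weaker inhibitor:
- compound 1 `CC(C)[C@H](NC(=O)COc1cccc2ccccc12)C(=O)N[C@@H](CC(=O)O)C(=O)COc1cccc2ccccc12` gives 19000 nM
- compound 2 `CC(C)[C@H](NC(=O)COc1cccc2ccccc12)C(=O)N[C@@H](CC(=O)O)C(=O)COc1cccc(C(F)(F)F)c1` gives 16600 nM
- compound 3 `CC(C)[C@H](NC(=O)COc1cccc2ccccc12)C(=O)N[C@@H](CC(=O)O)C(=O)COc1ccc(C#N)cc1` gives 26700 nM

Compound 3 stands level with the other two within the scatter, as shown by a 1.4-fold higher number from compound 1 to compound 3 (0.15 log units; within the scatter) and a 1.6-fold higher number from compound 2 to compound 3 (0.21 log units; within the scatter). Its values therefore give no ordering of the three compounds.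

The next compound is compound 4 `CC(C)[C@H](NC(=O)COc1cccc2ccccc12)C(=O)N[C@@H](CC(=O)O)C(=O)COc1ccc([N+](=O)[O-])cc1`, which has nitro in place of cyano on an aromatic carbon, para to a large group (nitro in place of cyano on an aromatic carbon). The rest of the structure is unchanged, including the shared core.

For the measured compounds named here, no measured step makes this exact exchange, so the evidence is indirect. The closest comparisons are the three changes to the group on the same oxygen. Replacing naphthalen-1-yl gives a 1.1-fold lower number from compound 1 to compound 2 (0.06 log units; within the scatter) and a 1.4-fold higher number from compound 1 to compound 3 (0.15 log units; within the scatter), while replacing 3-(trifluoromethyl)phenyl with 4-cyanophenyl gives a 1.6-fold higher number from compound 2 to compound 3 (0.21 log units; within the scatter). All three stay within the scatter, although each swaps a whole aryl group, a larger edit than the one at hand. On that basis, no step beyond the scatter is expected in this assay, and no direction can be assigned with confidence.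

The estimated step is a 1.2-fold lower number from compound 3 to compound 4 (0.08 log units; within the scatter).

For compound 4 the expected value is 22000 nM, with an estimated range from 10000 nM to 45000 nM.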

Compound 4, half-maximal inhibitory concentration: 22800 nM
Compound 4: the middle estimate sits 1.0-fold (0.02 log units) below what was measured, and the stated range covers the measured number.
By their numbers in this assay, from the lowest: compounds 2, 1, 4 and 3 (each within the scatter of the next).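

In this assay, this exchange keeps the phenyl ring and changes only the group on an aromatic carbon, para to a large group, unlike the earlier edits that replaced a whole aryl group, and it gives a 1.2-fold lower number from compound 3 to compound 4 (0.07 log units; within the scatter) as the reading. The 4-nitrophenyl group also stands level with the other aryl groups on the same oxygen, with a 1.4-fold higher number from compound 2 to compound 4 (0.14 log units; within the scatter) and a 1.2-fold higher number from compound 1 to compound 4 (0.08 log units; within the scatter) as the two further comparisons, so all four compounds now lie within the scatter of one another in every printed step. Nothing measured here gives a reason for this flat response.

Still open, on these data alone, is whether any group at this position can move the number beyond the scatter, for example an amine on the phenyl ring or a longer chain in place of the aryl group. Also open, as far as these compounds go, is whether the picture holds once the shared core itself is altered, as all four compounds carry it unchanged.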